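The source may report more compounds than this note shows. Statements on the series, on what has been measured and on what is new or still open speak of the compounds shown alone.

Measured so far, in a functional assay, tested at 200 ug/mL; on this read-out lower numbers stand for a stronger effect and higher numbers for a weaker effect at the one concentration tested:

- compound 1 `CCOC(=O)C1=C(C)N(c2ccccc2)C=CC1c1ccccc1`: -34%
- compound 2 `CCOC(=O)C1=C(C)N(c2ccc(F)cc2)C=CC1c1ccccc1`: -42.5%
- compound 3 `CCOC(=O)C1=C(C)N(c2ccc(Cl)cc2)C=CC1c1ccccc1`: -37.4%

These three share one core and differ only in the group on the ring attached to the nitrogen. Their numbers lie close together: the step of a number 8.5 percentage points lower from compound 1 to compound 2 (within the scatter), the step of a number 3.4 percentage points lower from compound 1 to compound 3 (within the scatter) and the step of a number 5.1 percentage points higher from compound 2 to compound 3 (within the scatter) all stay within the scatter, so compound 3 cannot be set apart from compound 1 or compound 2 in this assay; its number simply sits among the others.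

Compound 4 `CCOC(=O)C1=C(C)N(c2ccc(Br)cc2)C=CC1c1ccccc1` is not yet measured. It differs from compound 3 by bromo in place of chloro on an aromatic carbon. Within the data shown here, the steps that bear on this change are those in which a halogen entered or was exchanged at the same place: fluoro for hydrogen, chloro for hydrogen and chloro for fluoro. None of them moved the number beyond the scatter. On that basis the exchange of chloro for bromo is expected to give a step of a number 0.6 percentage points lower from compound 3 to compound 4 (within the scatter) in this assay, which is no change beyond the scatter. Compound 4 is therefore expected to give about -38%, with a range from -50% to -26%.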

Compound 4, a percentage reported as activity, at one concentration (the size of the read-out at that concentration, not a potency): -28.4%
For compound 4 the middle estimate is 9.6 percentage points below the measured one, and the stated range covers the measured number.
By their numbers in this assay, from the lowest: compounds 2, 3, 1 and 4 (each within the scatter of the next, the first and the last beyond it).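

In this assay, the ring attached to the nitrogen now gives its first step beyond the scatter (a number 14.1 percentage points higher from compound 2 to compound 4 (beyond the scatter)), so exchanging fluoro for bromo at this position has a measurable, though modest, effect on the read-out. The other two new steps do not separate bromo from its neighbours in the series (a number 9 percentage points higher from compound 3 to compound 4 (within the scatter); a number 5.6 percentage points higher from compound 1 to compound 4 (within the scatter)), so the bromo compound cannot be told apart from the chloro compound or from the compound with hydrogen at this position, and only the fluoro and bromo compounds stand clearly apart among the four. No measurement at hand accounts for the gap between these two compounds.

The compounds shown contain only hydrogen or a single halogen at this position, so it remains open how the read-out would respond to a larger or chemically different group there, such as an amine, a methoxy group or a carboxylic acid. From the compounds shown here alone, it is also open whether the fluoro and bromo compounds would still differ at other concentrations, since each number here comes from a single tested concentration and gives no potency.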